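Swapping Nitro for Chloro in an Antiproliferative Series

This account rests on a few compounds, and the source may have more. Where it says the series, first, only, none or still open, it means among the compounds named here.

Of the compounds shown here, three have been tested in a functional assay on HCT-116 cells (Homo sapiens) for antiproliferative activity, read by MTT assay, with a stated time of 48 h (on this read-out lower numbers stand for stronger inhibition and higher numbers for weaker inhibition), and a fourth awaits testing. Compound 1 `N#CC1=C(N)Oc2c(c3nc4ccccc4nc3c3ccccc23)C12C(=O)N(Cc1cnnn1-c1ccc(Cl)cc1)c1ccccc12` and compound 2 `N#CC1=C(N)Oc2c(c3nc4ccccc4nc3c3ccccc23)C12C(=O)N(Cc1cnnn1-c1ccc([N+](=O)[O-])cc1)c1ccccc12` share one core and differ in a single place, described as chloro in place of nitro on an aromatic carbon. Compound 3 `N#CC1=C(N)Oc2c(N)cc3nc4ccccc4nc3c2C12C(=O)N(Cc1cnnn1-c1ccc([N+](=O)[O-])cc1[N+](=O)[O-])c1ccccc12` carries a different core; the difference between the two cores is not broken down here. Compound 4 `N#CC1=C(N)Oc2c(N)cc3nc4ccccc4nc3c2C12C(=O)N(Cc1cnnn1-c1ccc(Cl)cc1[N+](=O)[O-])c1ccccc12` is built from compound 3 by chloro in place of nitro on an aromatic carbon. The change from compound 3 to compound 4 is the same kind of change as that from compound 2 to compound 1, not the same: around the place in compound 3 the chloro enters meta to a nitro group, while in compound 2 the place is only para to a large group.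

In this assay compound 1 reaches only a limit, > 50000 nM. Compound 2 likewise gives only a limit, > 50000 nM. Among the measured compounds shown here, compound 3 is the one compound with a number, 23900 nM. The step that the two limits leave unreadable from compound 2 to compound 1 therefore cannot be sized, and the limit of > 50000 nM in this assay, at which 2 of the 3 values shown sit, shows how little the two limits reveal.

For compound 4 the step is expected to be a 1.0-fold higher number from compound 3 to compound 4 (0.02 log units; within the scatter), close to no change, because a step that the two limits leave unreadable from compound 2 to compound 1 gives no readable size on which to build a larger expectation. Compound 4 is thus estimated at 25000 nM, with a likely span from 8000 nM to 50000 nM.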

Compound 4, half-maximal inhibitory concentration: 28700 nM
Compound 4: the middle estimate sits 1.1-fold (0.06 log units) below what was measured, within the range that was stated.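

In this assay, replacing nitro with chloro gives a 1.2-fold higher number from compound 3 to compound 4 (0.08 log units; within the scatter), so on this core the 2,4-dinitrophenyl and 4-chloro-2-nitrophenyl groups cannot be told apart by this read-out. The same swap on the other core, from compound 2 to compound 1, cannot be read, because both compounds give only a limit of the assay and not a number: the limit of > 50000 nM in this assay, at which 2 of the 4 values shown sit. The result therefore does not show that the change carries from one core to the other: it rests on a single readable pair, and the surroundings also differ, with the chloro entering meta to a nitro group in compound 4, whereas in compound 1 it is only para to a large group.

The compounds shown leave open how a carboxylic acid or a methyl group would read in this same place on either core, which would test whether this place responds to any change at all. They also leave open how the swap of nitro for chloro would read on the core of compound 3 without the nitro group that stays in compound 4.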